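Swapping the ring on a weak growth inhibitor

The compounds below may be only part of what the source reports. "The series", "measured", "known", "first", "only" and "open" are said of these compounds alone.

Measured in a functional assay on U-373MG ATCC cells for inhibition, with U373 MG (Homo sapiens) as the target, read by MTT assay, with a stated time of 7 days; a higher number here means a weaker inhibitor of growth, a lower number a stronger inhibitor of growth:
- compound 1 `C#CCn1nnc2c(C(N)=O)ncn2c1=O`: 37600 nM
- compound 2 `C[Si](C)(C)CCOCn1nnc2c(C(N)=O)ncn2c1=O`: 25300 nM
- compound 3 `Cc1cc(Cn2nnc3c(C(N)=O)ncn3c2=O)on1`: > 50000 nM, a limit and not a number

Compound 3 stands at the limit of > 50000 nM in this assay, at which 1 of the 3 values shown sits. So its true value is not known, and only a floor can be given for how it compares with the others. The two steps that reach it are an at least 1.3-fold higher number from compound 1 to compound 3 (0.12 log units; that floor lies within the scatter) and an at least 1.9-fold higher number from compound 2 to compound 3 (0.29 log units; that floor lies within the scatter). Neither sets it apart from its neighbours.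

The next compound is compound 4 `NC(=O)c1ncn2c(=O)n(Cc3c[nH]nn3)nnc12`, which keeps the shared core and the primary amide. Among the compounds with values here, the only change is 1H-1,2,3-triazol-4-yl in place of 3-methyl-1,2-oxazol-5-yl, on a saturated chain carbon bound to an aromatic nitrogen: 1H-1,2,3-triazol-4-yl in place of 3-methyl-1,2-oxazol-5-yl on a saturated chain carbon bound to an aromatic nitrogen.

All three measured steps alter the group at this same place. Within the data shown here, the only one with two real numbers is a 1.5-fold lower number from compound 1 to compound 2 (0.17 log units; within the scatter), and even that large swap of groups stays within the scatter. The new group is also close in size to the one it replaces, so no step beyond the scatter is expected, in either direction.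

The estimate means an at least 1.1-fold lower number from compound 3 to compound 4 (0.04 log units; that floor lies within the scatter), an expected difference that stays within the scatter.

Compound 4 is estimated at 45000 nM, with an expected range from 22000 nM to 90000 nM.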

Compound 4, concentration for 50% growth inhibition: > 50000 nM
Compound 4 ended at the assay's limit (the forecaster's own chance of this, stated with the estimate: 50%); middle value at least 1.1-fold (0.04 log units) away from the limit.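

In this assay compound 4 gives > 50000 nM and this is a limit of the assay, not a number, so a second five-membered aromatic ring at this place also ends without a readable value: the limit of > 50000 nM in this assay, at which 2 of the 4 values shown sit.

The step between compound 3 and compound 4 cannot be read, so the swap of 3-methyl-1,2-oxazol-5-yl for 1H-1,2,3-triazol-4-yl has no measurable size here, even though the entering ring carries 1 hydrogen-bond donor and the leaving ring 0. Against the two compounds with real values, the result reads as an at least 1.9-fold higher number from compound 2 to compound 4 (0.29 log units; that floor lies within the scatter) and as an at least 1.3-fold higher number from compound 1 to compound 4 (0.12 log units; that floor lies within the scatter) and neither floor goes beyond the scatter, so the new ring is not set apart from them either.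

Where compound 3 and compound 4 truly lie remains open, and so does the size of any difference between the two rings. Also open, on these data alone, is whether an amine, a carboxylic acid or a longer chain on the saturated chain carbon bound to the aromatic nitrogen would give a step beyond the scatter.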